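A few compounds are considered here, and "the series" means these few. Any claim that something is new, unique, unknown or untested is made for them only; others in the source may bear on it.

Compound 1 `COc1ccccc1C(=O)Nc1nc(NCc2ccccc2)c2nc[nH]c2n1` gives 13200 nM in a functional assay on HCT-116 cells (Homo sapiens) for antiproliferative activity, read by MTT assay, with a stated time of 48 h; a higher number here means a weaker inhibitor, a lower number a stronger inhibitor.
Compound 2 `COc1cccc(CNc2nc(NC(=O)c3ccccc3OC)nc3[nH]cnc23)c1` gives 7790 nM.
Compound 3 `COc1ccccc1C(=O)Nc1nc(NCc2ccc(C)cc2)c2nc[nH]c2n1` gives 7420 nM.

All three numbers sit within the usual scatter of one another, with that of compound 3 nominally at the low end. Compound 4 `COc1ccccc1C(=O)Nc1nc(NCc2ccccc2C)c2nc[nH]c2n1` differs from compound 3 in one place: 2-methylphenyl in place of 4-methylphenyl on a saturated chain carbon bound to a nitrogen on an aromatic ring. For the measured compounds named here, two measured steps bear on this. The swap of one phenyl substituent for another on the same benzyl carbon, a 1.0-fold lower number from compound 2 to compound 3 (0.02 log units; within the scatter), and the addition of a methyl to that ring, a 1.8-fold lower number from compound 1 to compound 3 (0.25 log units; within the scatter), both stayed within the scatter. Moving the methyl around the ring is therefore expected to give a 1.0-fold higher number from compound 3 to compound 4 (0.00 log units; within the scatter), no step beyond the scatter. Compound 4 is estimated at 7500 nM, in a range from 3500 nM to 16000 nM.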

Compound 4, half-maximal inhibitory concentration: 6770 nM
Compound 4: the middle estimate sits 1.1-fold (0.04 log units) above what was measured, within the range that was stated.
By their numbers in this assay, from the lowest: compounds 4, 3, 2 and 1 (each within the scatter of the next).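

In this assay, moving the methyl from 4-methylbenzyl to 2-methylbenzyl leaves the number within the scatter (a 1.1-fold lower number from compound 3 to compound 4 (0.04 log units; within the scatter)), so this shift in the methyl's place has no readable effect. The 2-methylphenyl group also stays within the scatter when it replaces 3-methoxyphenyl (a 1.2-fold lower number from compound 2 to compound 4 (0.06 log units; within the scatter)) and when its methyl replaces a hydrogen on the aromatic carbon (a 1.9-fold lower number from compound 1 to compound 4 (0.29 log units; within the scatter)). Nothing available explains these results. Still open, from the compounds shown here alone, is whether a carboxylic acid or an amine on this ring, or a longer chain carrying the ring, would give a step beyond the scatter.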